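Swapping the Ester Side Chain on a Weak Cardiac Agonist

A few compounds are considered here, and "the series" means these few. Any claim that something is new, unique, unknown or untested is made for them only; others in the source may bear on it.

Three compounds share one core and differ only in the group attached to a saturated ring carbon: pyridin-4-yl, pyridin-2-yl or pyridin-3-yl. In a functional assay (cardiac atrium) for agonist activity, with Cavia porcellus as the target (a lower number here means that less compound is needed, a higher number that more compound is needed for the effect), compound 1 `COCCO/C(O)=C1\C(C)=NC(C)=C([N+](=O)[O-])C1c1ccncc1` gives 37700 nM, compound 2 `COCCO/C(O)=C1\C(C)=NC(C)=C([N+](=O)[O-])C1c1ccccn1` gives 9700 nM, and compound 3 `COCCO/C(O)=C1\C(C)=NC(C)=C([N+](=O)[O-])C1c1cccnc1` gives 49400 nM. Compound 3 has the highest number of the three: the step of a 5.1-fold higher number from compound 2 to compound 3 (0.71 log units; beyond the scatter) lies beyond the scatter, whereas a 1.3-fold higher number from compound 1 to compound 3 (0.12 log units; within the scatter) is too small to count as a real difference. The remaining step, a 3.9-fold lower number from compound 1 to compound 2 (0.59 log units; beyond the scatter), completes the picture of what has been measured so far.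

Compound 4 `CC1=NC(C)=C([N+](=O)[O-])C(c2cccnc2)/C1=C(\O)OC(C)C` keeps the pyridin-3-yl group of compound 3 and alters the ester side chain instead: isopropyl in place of 2-methoxyethyl on an oxygen on an unsaturated carbon. Going by the values given here, none of the measured steps touches this part of the molecule; all three concern only the group on the saturated ring carbon, so they offer no direct guidance on the size or direction of this change. In the absence of such guidance, the expected step of a 1.1-fold lower number from compound 3 to compound 4 (0.04 log units; within the scatter) is none beyond the scatter, with a wide range to allow for movement either way. Compound 4 is therefore estimated at 45000 nM, within a range from 12000 nM to 160000 nM.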

Compound 4, half-maximal effective concentration: 28500 nM
The estimate for compound 4 lay 1.6-fold (0.20 log units) above the measured number; the range from low to high includes it.
By their numbers in this assay, from the lowest: compound 2; then compounds 4, 1 and 3 (each within the scatter of the next).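

Going by these compounds alone, this is the first look at the ester side chain, and in this assay replacing 2-methoxyethyl with isopropyl on this oxygen makes no real difference: a 1.7-fold lower number from compound 3 to compound 4 (0.24 log units; within the scatter) stays within the usual scatter. The swap takes the side chain from 4 heavy atoms to 3 and from 1 hydrogen-bond acceptor to 0, so with the pyridin-3-yl group in place, neither the oxygen of the 2-methoxyethyl chain nor its exact shape is needed to keep the number where it is. Nothing available here offers an explanation for this result.

The compounds shown leave open whether isopropyl would be tolerated equally well alongside the pyridin-2-yl group of compound 2, as this single pair speaks only for the pyridin-3-yl series. They also leave open how far this tolerance extends, for example to a longer chain such as n-hexyl, or to a side chain ending in an amine or a carboxylic acid, any of which could show whether the side chain can shift the number at all.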